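The source may report more compounds than this note shows. Statements on the series, on what has been measured and on what is new or still open speak of the compounds shown alone.

Measured in a functional assay on CCRF-CEM cells (Homo sapiens) for cytotoxicity; a lower number here means a stronger inhibitor, a higher number a weaker inhibitor:
- compound 1 `O=C(/C=C/C(=O)N1C/C(=C\c2ccc([N+](=O)[O-])cc2)C(=O)/C(=C/c2ccc([N+](=O)[O-])cc2)C1)Nc1ccc(Cl)c(Cl)c1`: 380 nM
- compound 2 `CC(=O)c1ccc(NC(=O)/C=C/C(=O)N2C/C(=C\c3ccc([N+](=O)[O-])cc3)C(=O)/C(=C/c3ccc([N+](=O)[O-])cc3)C2)cc1`: 360 nM
- compound 3 `O=C(/C=C/C(=O)N1C/C(=C\c2ccc([N+](=O)[O-])cc2)C(=O)/C(=C/c2ccc([N+](=O)[O-])cc2)C1)Nc1ccc(Cl)cc1`: 810 nM

In this assay compound 3 has the highest number of the set at 810 nM, and its steps to both other compounds lie beyond the scatter. The next analogue is compound 4 `Cc1cccc(C)c1NC(=O)/C=C/C(=O)N1C/C(=C\c2ccc([N+](=O)[O-])cc2)C(=O)/C(=C/c2ccc([N+](=O)[O-])cc2)C1`, which keeps the shared core and changes only the aryl group. The difference is 2,6-dimethylphenyl in place of 4-chlorophenyl on an amide-type nitrogen.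

Within the data shown here, three measured steps bear on this, all of them changes on the same aryl group. They are a 2.1-fold higher number from compound 1 to compound 3 (0.33 log units; beyond the scatter), a 2.3-fold higher number from compound 2 to compound 3 (0.35 log units; beyond the scatter) and a 1.1-fold lower number from compound 1 to compound 2 (0.02 log units; within the scatter). The first two are modest and the third lies within the scatter. Among the measured compounds shown here, none of the measured compounds carries a 2,6-dimethylphenyl group, so the data give no direct reading of this substitution.

With aryl changes so far moving the number only modestly, and compound 3 at the top of the set with 810 nM, a small move to a lower number is expected, not a large one. The expected change, which stays within the scatter, is a 1.4-fold lower number from compound 3 to compound 4 (0.13 log units; within the scatter). For compound 4 the estimated value is 600 nM, with an expected range of 250 nM to 1500 nM.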

Compound 4, half-maximal inhibitory concentration: 230 nM
Estimate against measurement, compound 4: 2.6-fold (0.42 log units) above; measured number outside the range, below it.
By their numbers in this assay, from the lowest: compounds 4, 2 and 1 (each within the scatter of the next); then compound 3.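

In this assay, among these compounds, replacing the aryl group on the amide-type nitrogen produces a larger shift than the earlier steps suggested (a 3.5-fold lower number from compound 3 to compound 4 (0.55 log units; beyond the scatter)), so this position has more room for change than the first three compounds showed. The other two comparisons lie within the scatter (a 1.6-fold lower number from compound 2 to compound 4 (0.19 log units; within the scatter); a 1.7-fold lower number from compound 1 to compound 4 (0.22 log units; within the scatter)), which places 2,6-dimethylphenyl with 4-acetylphenyl and 3,4-dichlorophenyl, while 4-chlorophenyl alone stands apart, and it shows that neither chlorine nor an acetyl group is needed on this aryl group to reach that level. No supporting measurement bears on why 4-chlorophenyl differs from the other three aryl groups.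

The compounds shown leave open whether both methyl groups of the 2,6-dimethylphenyl are needed, which an unsubstituted phenyl or a phenyl carrying a single methyl would help to settle. They also leave open how this position responds to an amine or a carboxylic acid on the aryl group, and whether the aryl group can be replaced by a longer alkyl chain.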